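The source may hold more compounds than are shown below. What is called first, only, known or untested is meant among the compounds shown, and "the series" means these compounds.

Two compounds measured in a physicochemical assay for lipophilicity, read by HPLC, in phosphate buffer, measured as chromatographic lipophilicity, at pH 7.4 (a higher number here means a more lipophilic compound, a lower number a more polar compound), set the frame. Compound 1, `COc1ccc2nc(C)cc(NCC(=O)Nc3cc(C)cc(C)c3)c2c1`, is the more polar of the pair: in this assay compound 1 gives 3.59. Compound 2, `COc1ccc2nc(C)cc(OCC(=O)Nc3c(C)cccc3C)c2c1`, stands at the top of the two numbers: in this assay compound 2 gives 4.55, a result that lies well beyond the scatter above that of compound 1.

Compound 3, `COc1ccc2nc(C)cc(OCC(=O)Nc3ccncc3)c2c1`, has not yet been measured. It differs from compound 2 in one place: pyridin-4-yl in place of 2,6-dimethylphenyl on an amide-type nitrogen. A pyridin-4-yl in place of a 2,6-dimethylphenyl on an amide-type nitrogen is expected to move the number downward, and by a clear margin rather than within the scatter. Going by the values given here, no measured pair here shows this exact exchange, so the size of the expected step rests on the change itself.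

The account expects that the step from compound 2 to compound 3 in this assay will be a number 2.05 log units lower from compound 2 to compound 3 (beyond the scatter). Compound 3 is thus estimated at 2.5, with a likely range from 1.9 to 3.1.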

Compound 3, distribution coefficient: 2.5
Estimate against measurement, compound 3: no gap at the digits printed; measured number inside the range.
By their numbers in this assay, from the lowest: compound 3; then compound 1; then compound 2.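

Going by these compounds alone, compounds 1 and 2 differ in more than one place, so their values could not be tied to any single change; compound 3 gives the first step that can be read at one position. On the amide-type nitrogen, pyridin-4-yl in place of 2,6-dimethylphenyl gives a number 2.05 log units lower from compound 2 to compound 3 (beyond the scatter) in this assay, so this position can carry a large change in the number while the rest of compound 2 stays the same. The exchange removes the methyl groups, brings in a ring nitrogen with a hydrogen-bond acceptor and lowers the heavy-atom count, all at once, and nothing at hand shows which of these accounts for the step.

The compounds shown leave open how the step divides between loss of the two methyl groups and entry of the ring nitrogen, which a plain phenyl on the same amide-type nitrogen would help to separate. They also leave open whether pyridin-3-yl at this position would give a similar number, and whether the same exchange would give a step of this size in compound 1.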